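The compounds below may be only part of what the source reports. "The series", "measured", "known", "first", "only" and "open" are said of these compounds alone.

Compound 1 `Cc1ccc(C(=O)NC(=S)N2CCc3c(OCCCCCOc4ccc(Cl)cc4)cccc32)cc1`: in an ADME assay on Huh-7 cells (Homo sapiens) for cytotoxicity (on this read-out higher numbers stand for lower toxicity in this test and lower numbers for higher toxicity in this test), compound 1 gives > 50000 nM, which is a limit of the test and not a number.
Compound 2 `O=C(NC(=S)N1CCc2c(OCCCCCOc3ccc(Cl)cc3)cccc21)c1cccnc1`: in this assay compound 2 gives 11100 nM.

Among the compounds with values here, compound 2 therefore holds the only actual number in this set; the other value is a limit. Within the data shown here, the single measured step, an at least 4.5-fold lower number from compound 1 to compound 2 (0.65 log units; beyond the scatter), came from exchanging the aromatic group that sits on the carbonyl carbon, and it moved the number toward higher toxicity.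

Compound 3 `O=C(NC(=S)N1CCc2c(OCCCCCOc3ccc(Cl)cc3)cccc21)c1cc2ccccc2s1` alters the same position once more: 1-benzothiophen-2-yl in place of pyridin-3-yl on a carbonyl carbon. The measured step is the only one that bears on this change, since it also replaced the group on the carbonyl carbon, and the limit of > 50000 nM in this assay, at which 1 of the 2 values shown sits, shows how far the carbocyclic partner of compound 1 pushed the number. Going from a nitrogen-containing ring to a larger group built from a five-membered sulfur ring fused to a carbon-only ring is a different kind of exchange, so the expectation is uncertain and leans only modestly back toward lower toxicity.

Compound 3 is expected to shift by the estimated step of a 1.8-fold higher number from compound 2 to compound 3 (0.26 log units; within the scatter). For compound 3 the estimated value is 20000 nM, with a likely range from 6000 nM to 60000 nM.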

Compound 3, half-maximal cytotoxic concentration: > 50000 nM
Compound 3 gave a limit, no number; the forecaster's own chance of this, stated with the estimate: 30%; at least 2.5-fold (0.39 log units) between middle value and limit.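

Exchanging pyridin-3-yl for 1-benzothiophen-2-yl on the carbonyl carbon gives an at least 4.5-fold higher number from compound 2 to compound 3 (0.65 log units; beyond the scatter) in this assay and so shows that a change at this position can move the number back up as well as down. Pyridin-3-yl now stands alone among the three groups shown here, since the 4-methylphenyl of compound 1 and the 1-benzothiophen-2-yl of compound 3 both end at a limit of the test, not at a number: the limit of > 50000 nM in this assay, at which 2 of the 3 values shown sit. Within the data shown here, these two groups differ in their rings and in their hetero atom, and what they have in common is only that neither carries the ring nitrogen of pyridin-3-yl, which is a pattern across these three compounds and no proof that the nitrogen is what matters.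

As far as these compounds go, both compound 1 and compound 3 sit at a limit, so the step between them cannot be read, and how far either lies beyond compound 2 stays unknown. Still open, from the compounds shown here alone, is how a plain phenyl, a pyridin-4-yl or a phenyl bearing an amine would read on this carbonyl carbon, any of which would help separate the role of the ring nitrogen from that of the rest of the group.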